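The source may hold more compounds than are shown below. What is called first, only, known or untested is meant among the compounds shown, and "the series" means these compounds.

Measured in an ADME assay on microsomes from liver (Mus musculus) for metabolic stability, read by HPLC, with a stated time of 4 h; a higher number here means that the compound lasts longer, a lower number that the compound disappears faster:
- compound 1 `CN(C)c1ccc2cc(-c3ccccc3F)c(N)nc2c1`: < 0.1 h, a limit of the assay and not a number
- compound 2 `CN(C)c1ccc2cc(-c3ccccc3Cl)c(N)nc2c1`: 0.13 h
- compound 3 `CN(C)c1ccc2cc(-c3ccc(Cl)cc3)c(N)nc2c1`: 0.18 h

Compound 3, at 0.18 h, stands within the scatter of compound 2, as a 1.4-fold higher number from compound 2 to compound 3 (0.14 log units; within the scatter) shows. Only these two compounds give numbers, and both lie close to the limit reported for compound 1.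

Compound 4 `CN(C)c1ccc2cc(-c3ccccn3)c(N)nc2c1` has pyridin-2-yl in place of 4-chlorophenyl on an aromatic carbon. Among the measured compounds shown here, none of the measured steps brings in a ring with a hetero atom, so they bear on this change only indirectly. They show how far changes to the aryl group have moved the half-life in this series. The two steps that start from the limit, an at least 1.3-fold higher number from compound 1 to compound 2 (0.11 log units; that floor lies within the scatter) and an at least 1.8-fold higher number from compound 1 to compound 3 (0.25 log units; that floor lies within the scatter), are only floors. For the measured compounds named here, the one fully measured step, a 1.4-fold higher number from compound 2 to compound 3 (0.14 log units; within the scatter), stays within the scatter. No step beyond the scatter, and no firm direction, is therefore expected in this assay. The expected change is no change at the digits printed from compound 3 to compound 4 (within the scatter). A result at the limit, as for compound 1, remains possible. For compound 4 the estimated half-life is 0.18 h, with an expected range from 0.1 h to 0.4 h.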

Compound 4, half-life: < 0.1 h
Compound 4: only a limit was reported; the forecaster's own chance of this, stated with the estimate: 20%; middle value at least 1.8-fold (0.25 log units) away from the limit.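

Pyridin-2-yl is the only ring with a hetero atom among the compounds shown at this position, ortho to the amino group, and in this assay compound 4 gives only a limit of the assay and not a number. Against the two compounds with measured half-lives the result gives only floors, an at least 1.8-fold lower number from compound 3 to compound 4 (0.25 log units; that floor lies within the scatter) and an at least 1.3-fold lower number from compound 2 to compound 4 (0.11 log units; that floor lies within the scatter), so both steps point the same way but neither is shown to pass the scatter, while the remaining step, to the other compound reported as a limit, cannot be read. What the result adds is that a ring with one nitrogen at this position gives a reading at the limit, as a 2-fluorophenyl ring did, and not a measurable half-life as the two chlorophenyl rings did: the limit of < 0.1 h in this assay, at which 2 of the 4 values shown sit.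

The compounds shown leave open how large the real step from the chlorophenyl compounds to compound 4 is, since the limit hides its full size. They also leave open whether pyridin-3-yl, pyridin-4-yl or a methoxy-substituted phenyl at this position, or a replacement of the dimethylamino group, would give a half-life clear of the limit.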